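Aryl to acyl exchange on the hydrazide nitrogen: compound 4

A few compounds are considered here, and "the series" means these few. Any claim that something is new, unique, unknown or untested is made for them only; others in the source may bear on it.

Compound 2 `Cc1cccc(NNC(=O)c2ccccc2NS(=O)(=O)c2cnc(O)nc2O)c1` carries a 3-methylphenyl on an amine nitrogen whose other neighbour is an amide-type nitrogen. In a functional assay on MDA-MB-231 cells (Homo sapiens) for antiproliferative activity, read by MTT assay, with a stated time of 24 h (a higher number here means a weaker inhibitor, a lower number a stronger inhibitor), compound 2 gives > 20000 nM, which is a limit of the assay and not a number. For the measured compounds named here, compound 2 therefore stands at the weak end of what the series shows so far, on the line (the limit of > 20000 nM in this assay, at which 2 of the 3 values shown sit), with no measured step of its own.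

Compound 4 `O=C(NNC(=O)c1ccccc1NS(=O)(=O)c1cnc(O)nc1O)c1cccc(Cl)c1` differs from compound 2 by (3-chlorophenyl)carbonyl in place of 3-methylphenyl on an amine nitrogen.

Going by the values given here, one measured step bears on this. Compound 1 `Cc1ccccc1NNC(=O)c1ccc(NS(=O)(=O)c2cnc(O)nc2O)cc1` in this assay gives > 20000 nM, again a limit. Compound 3 `Cc1ccccc1C(=O)NNC(=O)c1ccc(NS(=O)(=O)c2cnc(O)nc2O)cc1` in this assay gives 7040 nM. The step of an at least 2.8-fold lower number from compound 1 to compound 3 (0.45 log units; beyond the scatter) turns a limit into a number by (2-methylphenyl)carbonyl in place of 2-methylphenyl on an amine nitrogen. Among the compounds with values here, the change to compound 4 is of the same kind, (3-chlorophenyl)carbonyl in place of 3-methylphenyl on an amine nitrogen, though the chlorine for methyl exchange has no measured counterpart here, and compound 2 sits on a limit, so the size of the step cannot be fixed.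

Compound 4 is therefore expected near 8000 nM, within 3000 nM to 20000 nM. The expected step of an at least 2.5-fold lower number from compound 2 to compound 4 (0.39 log units; beyond the scatter) is a drop of at least modest size.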

Compound 4, half-maximal inhibitory concentration: 4420 nM
For compound 4 the middle estimate is 1.8-fold (0.26 log units) above the measured one; the measured number falls inside the stated range.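

In this assay compound 2 gives > 20000 nM, a limit of the assay and not a number, and it is not alone there: the limit of > 20000 nM in this assay, at which 2 of the 4 values shown sit.

With an at least 4.5-fold lower number from compound 2 to compound 4 (0.65 log units; beyond the scatter), the exchange of an aryl group for an arylcarbonyl group on the amine nitrogen turns a limit into a number on a second core, as an at least 2.8-fold lower number from compound 1 to compound 3 (0.45 log units; beyond the scatter) did on the core of compound 1. Across the four compounds, the two with a carbonyl on this nitrogen give numbers and the two without it sit on the limit, and no compound shown goes against that split.

The step from compound 2 changes the carbonyl and swaps methyl for chlorine in one move, so the compounds shown do not separate the share of each, and the true size of the step stays unknown while compound 2 rests on a limit. Also open, going by these compounds, is how this position responds when the aryl ring of the arylcarbonyl group gives way to something else, such as a longer alkyl chain, or when the chlorine gives way to an amine or a carboxylic acid.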